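Adding a Methylsulfonyl Group to Compound 2

This account rests on a few compounds, and the source may have more. Where it says the series, first, only, none or still open, it means among the compounds named here.

Measured compounds:
compound 1 `C/C(=C\c1cc(-c2ccc(C)nc2)co1)C(N)=O`: > 50000 nM, which is a limit of the assay rather than a number
compound 2 `C/C(=C\c1cc(-c2ccccc2)cs1)C(N)=O`: 12700 nM
compound 3 `C/C(=C\c1cc(-c2ccccc2C)cs1)C(N)=O`: 19400 nM

In a functional assay on HeLa cells (Homo sapiens) for cytotoxicity, read by CCK-8 assay, with a stated time of 24 h (on this read-out lower numbers stand for stronger inhibition and higher numbers for weaker inhibition), compound 2 gives 12700 nM, the lowest of the two numbers shown. Its nearest neighbour is compound 3, and the step of a 1.5-fold higher number from compound 2 to compound 3 (0.18 log units; within the scatter) shows that a methyl on the ring made no difference beyond the scatter. Compound 4 `C/C(=C\c1cc(-c2ccc(S(C)(=O)=O)cc2)cs1)C(N)=O` differs from compound 2 by methylsulfonyl in place of hydrogen on an aromatic carbon. Among the compounds with values here, no measured step involves this group or this place, so the only guide is that the one ring change seen so far left the number essentially unchanged. The step of a 1.2-fold higher number from compound 2 to compound 4 (0.07 log units; within the scatter) is therefore expected to stay within the scatter. Compound 4 is estimated at 15000 nM, within a range from 4000 nM to 50000 nM.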

Compound 4, half-maximal inhibitory concentration: > 50000 nM
Compound 4: only a limit was reported (the forecaster's own chance of this, stated with the estimate: 25%); at least 3.3-fold (0.52 log units) between middle value and limit.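

In this assay, methylsulfonyl on this aromatic carbon gives an at least 3.9-fold higher number from compound 2 to compound 4 (0.59 log units; beyond the scatter), so this ring of compound 2 does not tolerate every change, whereas the methyl step, a 1.5-fold higher number from compound 2 to compound 3 (0.18 log units; within the scatter), stayed within the scatter. Compound 4 gives > 50000 nM, which is a limit and not a number, so the full size of the step stays unknown: the limit of > 50000 nM in this assay, at which 2 of the 4 values shown sit.

As far as these compounds go, whether an amine or a carboxylic acid on this same carbon would also raise the number remains open. So does whether a methoxy group there would leave it unchanged.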